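The source may report more compounds than this note shows. Statements on the series, on what has been measured and on what is new or still open speak of the compounds shown alone.

Three compounds share one core and differ only in the group on the carbonyl carbon of the side chain. Compound 1 `COC1CN(C(=O)/C=C/c2ccncc2-c2ccc3ccccc3c2)C1` carries a 3-methoxyazetidin-1-yl group there, and in an assay on a protein complex for inhibition of CDK8/Cyclin C (Homo sapiens), with a stated time of 1 h, tested at 10 uM (on this read-out higher numbers stand for more inhibition at the one concentration tested (going by the name of the read-out) and lower numbers for less inhibition), compound 1 gives 100%. Compound 2 `COC(=O)/C=C/c1ccncc1-c1ccc2ccccc2c1` has methoxy in its place, and in this assay compound 2 gives 102%. Compound 3 `O=C(O)/C=C/c1ccncc1-c1ccc2ccccc2c1` carries hydroxy on that carbon, and in this assay compound 3 gives 102%. Compound 3 thus stands level with compound 2 at the digits shown, together the highest of the three numbers, with compound 1 nearest behind it: the step of a number 2 percentage points higher from compound 1 to compound 3 (within the scatter) and the step of no change at the digits printed from compound 2 to compound 3 (within the scatter) both lie within the scatter, as does a number 2 percentage points higher from compound 1 to compound 2 (within the scatter).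

Compound 4 `O=C(O)CCNC(=O)/C=C/c1ccncc1-c1ccc2ccccc2c1` extends this series: (2-carboxyethyl)amino in place of hydroxy on a carbonyl carbon. The two steps that bear on it, from compound 1 to compound 3 and from compound 2 to compound 3, changed the same carbonyl carbon and moved the read-out by nothing beyond the scatter, so no shift beyond the scatter is expected here either in this assay. For compound 4 the expected step is a number 3 percentage points lower from compound 3 to compound 4 (within the scatter). Compound 4 is therefore estimated at 99%, within a range from 88% to 105%.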

Compound 4, a percentage reported as inhibition, at one concentration (the size of the read-out at that concentration, not a potency): 91%
Beside the measured number, compound 4's estimate is 8 percentage points above it, and the stated range covers the measured number.
By their numbers in this assay, from the lowest: compounds 4, 1, 2 and 3 (each within the scatter of the next, the first and the last beyond it).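

Until now, every change on the carbonyl carbon had stayed within the scatter in this assay. Within the data shown here, with (2-carboxyethyl)amino at this position, the first steps beyond the scatter appear, both modest (a number 11 percentage points lower from compound 3 to compound 4 (beyond the scatter) and a number 11 percentage points lower from compound 2 to compound 4 (beyond the scatter)), while the comparison with the 3-methoxyazetidin-1-yl group stays within it (a number 9 percentage points lower from compound 1 to compound 4 (within the scatter)), so the size of the change depends on which group it replaces. No measurement shown accounts for this modest change.

The compounds shown leave open whether the amide nitrogen or the terminal carboxylic acid of the new chain goes with the lower number, which an ethylamino group or the methyl ester of the same chain could separate. Since each number comes from a single concentration, they also leave open how far the potencies of these compounds differ.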